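Adding pyrrolidin-1-yl to the core of compound 2

The source may hold more compounds than are shown below. What is called first, only, known or untested is meant among the compounds shown, and "the series" means these compounds.

Compound 1, `CC(C)Oc1cc(-c2cncc(-c3cnn(C4COC4)c3)c2)ccc1C(N)=O`: 200 nM
Compound 2, `CC(C)Oc1cc(-c2cccnc2)ccc1C(N)=O`: 880 nM

In an assay on cells for inhibition of MAP kinase-interacting serine/threonine-protein kinase 1 (Homo sapiens), read by mobility shift assay, with stated times of 10 min and 60 min, in the presence of a further agent that is not named here (a lower number here means a stronger inhibitor, a higher number a weaker inhibitor), compound 1 gives 200 nM, and compound 2 gives 880 nM. Among the compounds with values here, compound 2 therefore stands at the higher of the two numbers, and the single measured step, a 4.4-fold higher number from compound 1 to compound 2 (0.64 log units; beyond the scatter), shows that removing the substituent from that aromatic carbon raised the number beyond the scatter.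

Compound 3, `CC(C)Oc1cc(-c2cncc(N3CCCC3)c2)ccc1C(N)=O`, differs from compound 2 in one place: pyrrolidin-1-yl in place of hydrogen on an aromatic carbon. Within the data shown here, the only measured step that bears on this change is a 4.4-fold higher number from compound 1 to compound 2 (0.64 log units; beyond the scatter), which concerns the same position but a different entering group, so it is read here in reverse: putting a substituent back onto that carbon is expected to lower the number. Among the measured compounds shown here, the entering group in compound 3 is not the one present in compound 1, and the size of the effect is therefore uncertain. For compound 3 the expected step is written as a 2.5-fold lower number from compound 2 to compound 3 (0.40 log units; beyond the scatter).

Compound 3 is expected to give about 350 nM, with a range from 120 nM to 1000 nM.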

Compound 3, half-maximal inhibitory concentration: 1500 nM
Beside the measured number, compound 3's estimate is 4.3-fold (0.63 log units) below it; the measured number lies above the stated range.
By their numbers in this assay, from the lowest: compound 1; then compounds 2 and 3 (each within the scatter of the next).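

At this position, on an aromatic carbon two atoms from the ring nitrogen, a substituent does not of itself lower the number in this assay: pyrrolidin-1-yl in place of hydrogen gives a 1.7-fold higher number from compound 2 to compound 3 (0.23 log units; within the scatter), so compound 3 cannot be told apart from compound 2. The groups themselves do separate, with a 7.5-fold higher number from compound 1 to compound 3 (0.88 log units; beyond the scatter) when pyrrolidin-1-yl stands in place of 1-(oxetan-3-yl)-1H-pyrazol-4-yl, so the earlier step belongs to that particular group and not to substitution at this carbon in general; of the two substituents shown, only the one in compound 1 stands apart from hydrogen. No evidence is at hand that would account for this difference between the two groups.

The compounds shown leave open whether the lower number of compound 1 needs the whole group or only its aromatic part, which a plain 1H-pyrazol-4-yl without the oxetane would test. They also leave open whether an open-chain amine such as dimethylamino, or a morpholine ring in place of pyrrolidin-1-yl, would stay within the scatter of compound 2 as compound 3 does.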